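Methyl to Hydrogen on the Ring Nitrogen: Cell Tolerance

This account rests on a few compounds, and the source may have more. Where it says the series, first, only, none or still open, it means among the compounds named here.

Compound 1 `CC(NC(=O)c1ncc([N+](=O)[O-])n1C)c1ccc(F)cc1` in a toxicity assay on HEK293 cells (Homo sapiens) for inhibition, read by resazurin assay, with a stated time of 24 h (a lower number here means that less compound is tolerated, a higher number that more compound is tolerated), gives > 100000 nM, which is a limit of the assay, not a number.
Compound 2 `Cn1c([N+](=O)[O-])cnc1C(=O)NCc1ccccn1` in this assay gives > 100000 nM, again a limit.
Compound 3 `CC(NC(=O)c1ncc([N+](=O)[O-])[nH]1)c1ccc(F)cc1` in this assay gives > 100000 nM, also a limit.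

Compound 1 and compound 3 differ by hydrogen in place of methyl on an aromatic nitrogen, and the step that the two limits leave unreadable from compound 1 to compound 3 cannot be sized, because of the limit of > 100000 nM in this assay, at which 3 of the 3 values shown sit. How the core of compound 2 differs from that of compound 1 is not broken down here.

Compound 4 `O=C(NCc1ccccn1)c1ncc([N+](=O)[O-])[nH]1` has not been measured. It differs from compound 2 by hydrogen in place of methyl on an aromatic nitrogen, the same change as from compound 1 to compound 3, made at the same place. The step of a number no higher from compound 2 to compound 4 (the limit leaves the size open) is expected to be unreadable in the same way, since compound 1 and compound 3 both sit at the limit. Compound 4 is estimated at 100000 nM, most likely reported only as a limit.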

Compound 4, half-maximal cytotoxic concentration: > 100000 nM
Compound 4 was reported as a limit; the forecaster's own chance of this, stated with the estimate: 85%; the middle value lies on the limit itself.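

No step can be read from compound 2 to compound 4, because both sit at the same limit, which is not a number: the limit of > 100000 nM in this assay, at which 4 of the 4 values shown sit.

The compounds shown leave open whether hydrogen in place of methyl on an aromatic nitrogen changes cell tolerance at all in this assay.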